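The source may hold more compounds than are shown below. What is called first, only, known or untested is meant among the compounds shown, and "the series" means these compounds.

Measured compounds in a functional assay on HepG2 cells (Homo sapiens) for cytotoxicity, read by MTT assay, with a stated time of 48 h; on this read-out lower numbers stand for stronger inhibition and higher numbers for weaker inhibition:
compound 1 `COc1cc(-c2nnc3n2NC(c2ccco2)C(C(=O)c2cccs2)S3)cc(OC)c1OC`: 64100 nM
compound 2 `COc1cc(-c2nnc3n2NC(c2cccs2)C(C(=O)c2ccc(C)cc2)S3)cc(OC)c1OC`: 3700 nM
compound 3 `COc1ccc(C(=O)C2Sc3nnc(-c4cc(OC)c(OC)c(OC)c4)n3NC2c2cccs2)cc1`: 68000 nM

Compound 1 gives the second highest of the three numbers; compound 3 sits nearest, within the scatter, while compound 2 sits far lower, beyond the scatter. The unmeasured compound 4 `COc1cc(-c2nnc3n2NC(c2ccco2)C(C(=O)c2ccc(O)cc2)S3)cc(OC)c1OC` differs from compound 1 in one place: 4-hydroxyphenyl in place of thiophen-2-yl on a carbonyl carbon.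

Among the compounds with values here, only one step between measured compounds is known, and it concerns a different change on the same carbonyl-borne ring: an 18-fold higher number from compound 2 to compound 3 (1.26 log units; beyond the scatter). Within the data shown here, it shows that the group on the aryl ring of the (aryl)carbonyl part can move the number strongly, but it says nothing direct about swapping thiophen-2-yl for 4-hydroxyphenyl, and no pair with a hydroxy group has been measured. The direction of the step in this assay from compound 1 to compound 4 therefore cannot be read from the data; a modest change in either direction would not surprise.

Compound 4 is estimated at 40000 nM (range 8000 nM to 150000 nM), which is expected to mean a 1.6-fold lower number from compound 1 to compound 4 (0.20 log units; within the scatter).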

Compound 4, half-maximal inhibitory concentration: > 100000 nM
Compound 4 gave a limit, no number (the forecaster's own chance of this, stated with the estimate: 15%); middle value at least 2.5-fold (0.39 log units) from the limit.
By their numbers in this assay, from the lowest: compound 2; then compounds 1 and 3 (each within the scatter of the next). At a limit, above all of these: compound 4.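

In this assay compound 4 gives a limit and no number: the limit of > 100000 nM in this assay, at which 1 of the 4 values shown sits. The new step reads an at least 1.5-fold higher number from compound 1 to compound 4 (0.19 log units; that floor lies within the scatter), so the swap of thiophen-2-yl for 4-hydroxyphenyl on a carbonyl carbon is not shown to move the number beyond the scatter, although the limit leaves room for a larger change. It does add one thing the earlier compounds could not show: with a hydroxy group entering at this place, the only such compound shown gives no sign of a lower number than compound 1.

The compounds shown do not separate the change of ring from the hydroxy group, as a plain phenyl at this carbonyl carbon is absent from them. They also leave open how an amine or a carboxylic acid on that phenyl ring would read in this assay.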